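A Salicylamide in Place of an Amidine on a Bicyclic Core

The source may hold more compounds than are shown below. What is called first, only, known or untested is meant among the compounds shown, and "the series" means these compounds.

Of the compounds shown here, two of this small set have been tested in a functional assay on the whole organism (strain albino) for inhibition, with Rattus norvegicus as the target, read by paw edema, with stated times of 1 h and 2 h, at a dose of 20 mmol/kg by the intraperitoneal route; on this read-out higher numbers stand for more inhibition at the one dose given (going by the name of the read-out) and lower numbers for less inhibition. Compound 1 `COc1ccc(N/C=N/C2=C(C#N)C3C(N4CCCC4)CCCCN3C(=O)N2c2ccccc2)cc1` gives 37.2% in this assay, the lower of the two numbers. Compound 2 `N#Cc1c2n(c(=O)n(-c3ccccc3)c1=N)CCCCC2N1CCCC1` gives 88.7% in this assay, a number that lies beyond the scatter above that of compound 1. Compound 3 `N#CC1=C(NC(=O)c2ccccc2O)N(c2ccccc2)C(=O)N2CCCCC(N3CCCC3)C12` has not yet been measured in this assay. It differs from compound 1 in one place: a group of 10 heavy atoms (7 carbon, 1 nitrogen, 2 oxygen; one six-membered aromatic ring of carbon only) in place of a group of 11 heavy atoms (8 carbon, 2 nitrogen, 1 oxygen; one six-membered aromatic ring of carbon only), on a double-bonded ring carbon The new group enters on a double-bonded ring carbon of the shared core, next to the ring nitrogen and next to the ring atom that bears a cyano group. Within the data shown here, no step between two measured compounds that differ in only one place is available, so the effect of such an exchange cannot be read from a related pair, and the expectation rests on the two numbers alone. Compound 3 is estimated to give 52% in this assay, with a likely range from 25% to 80%. This estimate implies an expected upward step of a number 14.8 percentage points higher from compound 1 to compound 3 (beyond the scatter), a moderate gain that may not exceed the scatter.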

Compound 3, a percentage reported as inhibition, in the whole organism at one dose (the size of the read-out at that dose, not a potency): 53.8%
For compound 3 the middle estimate is 1.8 percentage points below the measured one; the range from low to high includes it.
By their numbers in this assay, from the lowest: compound 1; then compound 3; then compound 2.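

In this assay, among these compounds, putting ((2-hydroxyphenyl)carbonyl)amino in place of the amidine on the double-bonded ring carbon gives a number 16.6 percentage points higher from compound 1 to compound 3 (beyond the scatter), the first reading of a change at this position alone. The result shows that this place on the shared core can take a different group and still give a modest gain beyond the usual variation between repeat measurements, with a six-membered aromatic ring of carbon only present in both the old group and the new one. The exchange also alters the linking atoms and adds a hydrogen-bond donor, and nothing available here separates these differences or explains the step.

A plain benzoylamino group, an acetylamino group or a free amine on the same carbon could show whether the hydroxyl, the carbonyl or the aromatic ring matters most for the gain. Among the compounds shown here, no step between compounds that differ in one place connects compound 2 to the others, so its higher number cannot be traced to any single structural change.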